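The compounds below may be only part of what the source reports. "The series", "measured", "known", "first", "only" and "open" are said of these compounds alone.

Within the data shown here, compound 3 `O=C(NC(=S)Nc1nc2cc(Br)ccc2s1)c1ccc([N+](=O)[O-])cc1` gives, in a functional assay on MCF7 cells (Homo sapiens) for cytotoxicity, read by MTT assay, with a stated time of 24 h (a lower number here means a stronger inhibitor, a higher number a weaker inhibitor), a value of 32400 nM, the lowest of the two numbers so far. Compound 2 `O=C(NC(=S)Nc1nc2cc([N+](=O)[O-])ccc2s1)c1ccccc1` gives 41600 nM in this assay, a value within the scatter of compound 3. Compound 1 `CCCCC(=O)NC(=S)Nc1nc2cc([N+](=O)[O-])ccc2s1` reaches only the limit of > 100000 nM in this assay, which is a limit rather than a number (the limit of > 100000 nM in this assay, at which 1 of the 3 values shown sits). Among the measured compounds shown here, the one step between measured compounds, an at least 2.4-fold lower number from compound 1 to compound 2 (0.38 log units; beyond the scatter), changes the group on the carbonyl carbon and so says nothing about the fused core. Compound 4 `O=C(NC(=S)Nc1nc2cc([N+](=O)[O-])ccc2s1)c1ccc([N+](=O)[O-])cc1` differs from compound 3 in that (nitro in place of bromo on an aromatic carbon). For the measured compounds named here, no measured step bears on this change, so the step of a 1.1-fold lower number from compound 3 to compound 4 (0.03 log units; within the scatter) is expected to stay within the scatter. Compound 4 is therefore estimated at 30000 nM, with a range from 12000 nM to 80000 nM.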

Compound 4, half-maximal inhibitory concentration: 35200 nM
Compound 4: the middle estimate sits 1.2-fold (0.07 log units) below what was measured, within the range that was stated.
By their numbers in this assay, from the lowest: compounds 3, 4 and 2 (each within the scatter of the next). At a limit, above all of these: compound 1.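

Among these compounds, this is the first look at the aromatic carbon on the shared core, and in this assay the step of a 1.1-fold higher number from compound 3 to compound 4 (0.04 log units; within the scatter) shows that nitro in place of bromo there changes nothing measurable. Nitro in place of hydrogen on an aromatic carbon also gives a step within the scatter, a 1.2-fold lower number from compound 2 to compound 4 (0.07 log units; within the scatter) and 4-nitrophenyl in place of butyl gives an at least 2.8-fold lower number from compound 1 to compound 4 (0.45 log units; beyond the scatter) as a second step beyond it. Compound 1 stands at a limit, not a number: the limit of > 100000 nM in this assay, at which 1 of the 4 values shown sits.

On these data alone, whether an amine or a carboxylic acid on that aromatic carbon would give a step beyond the scatter stays open. So does the effect of a longer chain on the carbonyl carbon.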